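Replacing pyrrolidin-3-yl with cyclopropyl on the shared core

The source may report more compounds than this note shows. Statements on the series, on what has been measured and on what is new or still open speak of the compounds shown alone.

Three compounds share one core and differ in the group on an aromatic nitrogen: compound 1 `CCn1nc(CC(=O)Nc2ccc(OC(F)(F)F)c(Cl)c2)c2ccccc2c1=O`, compound 2 `O=C(O)Cn1nc(CC(=O)Nc2ccc(OC(F)(F)F)c(Cl)c2)c2ccccc2c1=O` and compound 3 `O=C(Cc1nn(C2CCNC2)c(=O)c2ccccc12)Nc1ccc(OC(F)(F)F)c(Cl)c1`. In a physicochemical assay for lipophilicity, at pH 7.4 (a lower number here means a more polar compound, a higher number a more lipophilic compound), compound 1 gives 5.42, compound 2 gives 2.92 and compound 3 gives 3.03. Compound 3 therefore sits far under compound 1 and cannot be told apart from compound 2, with a number 0.11 log units higher from compound 2 to compound 3 (within the scatter).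

Compound 4 `O=C(Cc1nn(C2CC2)c(=O)c2ccccc12)Nc1ccc(OC(F)(F)F)c(Cl)c1` has not yet been measured. It carries cyclopropyl in place of pyrrolidin-3-yl on an aromatic nitrogen.

Within the data shown here, two measured steps bear on this change. Pyrrolidin-3-yl in place of ethyl on an aromatic nitrogen gave a number 2.39 log units lower from compound 1 to compound 3 (beyond the scatter), and carboxy in place of methyl on a saturated chain carbon gave a number 2.50 log units lower from compound 1 to compound 2 (beyond the scatter). Both are large. Cyclopropyl is carbon only, like the ethyl of compound 1 at 5.42, so most of the first step is expected to reverse in this assay. Among the measured compounds shown here, no measured compound carries cyclopropyl itself, which keeps the range wide. The expected rise is a number 2.17 log units higher from compound 3 to compound 4 (beyond the scatter). For compound 4 the estimate is 5.2, with an expected range from 4.7 to 5.7.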

Compound 4, distribution coefficient: 5.43
Beside the measured number, compound 4's estimate is 0.23 log units below it; low and high end bracket the measured number.
By their numbers in this assay, from the lowest: compounds 2 and 3 (each within the scatter of the next); then compounds 1 and 4 (each within the scatter of the next).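

In this assay, the change gives a number 2.40 log units higher from compound 3 to compound 4 (beyond the scatter), which shows that a ring on this aromatic nitrogen does not by itself go with a low number: the three-membered ring of carbon only reads high, where the five-membered ring with a nitrogen read low. The comparison with carboxymethyl, at a number 2.51 log units higher from compound 2 to compound 4 (beyond the scatter), is of similar size, so both groups holding hetero atoms stand well apart from cyclopropyl at this position. Cyclopropyl and ethyl cannot be told apart, with a number 0.01 log units higher from compound 1 to compound 4 (within the scatter), so for these two carbon-only groups, closing the group into a ring makes no measurable difference in this reading.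

No measurement shown here explains why the numbers fall this way.

Going by these compounds, whether a larger carbon-only group, such as cyclohexyl or a longer chain, would give a similar number remains open. On these data alone, it is also open how much of the gap belongs to the nitrogen of pyrrolidin-3-yl and how much to its ring size: cyclopentyl, a five-membered ring of carbon only, and tetrahydrofuran-3-yl, with oxygen in that ring, would help separate the two.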